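Des-ethoxy analogue of a thiophene-linked biaryl propanoic acid

This account rests on a few compounds, and the source may have more. Where it says the series, first, only, none or still open, it means among the compounds named here.

Measured so far:
compound 1 `Cc1cccc(C)c1-c1cccc(COc2csc(CCC(=O)O)c2)c1` — 135%
compound 2 `Cc1cccc(C)c1-c1cccc(COc2ccc(CC3SC(=O)NC3=O)s2)c1` — "not determined" (no result reported)
compound 3 `CCO[C@H](CC(=O)O)c1ccc(OCc2cccc(-c3c(C)cccc3C)c2)s1` — 147%

In a functional assay on cells for agonist activity at Free fatty acid receptor 1 (Homo sapiens), read by calcium flux (a lower number here means a smaller maximal response, a higher number a larger maximal response), compound 3 gives 147%, the higher of the two numbers available. Compound 1 gives 135% in this assay, a reading that sits below that of compound 3 by more than the scatter of repeated measurements. Compound 2 carries a thiazolidinedione in place of the acid and returned "not determined" (no result reported) in this assay, so it adds nothing to the comparison.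

The next compound, compound 4 `Cc1cccc(C)c1-c1cccc(COc2ccc(CCC(=O)O)s2)c1`, is the des-ethoxy counterpart of compound 3. The change is hydrogen in place of ethoxy on a saturated chain carbon bound to an aromatic carbon and a saturated chain carbon; read one bond further out, 2-carboxy-1-ethoxyethyl becomes 2-carboxyethyl. Going by the values given here, no measured pair shows this step directly, so its size is not known from the series; compound 1, which also carries a plain 2-carboxyethyl chain on its thiophene, is the closest guide.

The step from compound 3 to compound 4 is expected to be a modest decrease, estimated at a number 10 percentage points lower from compound 3 to compound 4 (within the scatter), roughly at the edge of the scatter. Compound 4 is therefore expected to reach about 137%, within a range of 115% to 160%, because compound 1 reaches 135% with the same unsubstituted chain.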

Compound 4, largest response reached (Emax), in percent of the reference or control that the assay uses: 140%
Compound 4: the middle estimate sits 3 percentage points below what was measured; low and high end bracket the measured number.
By their numbers in this assay, from the lowest: compounds 1, 4 and 3 (each within the scatter of the next, the first and the last beyond it).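

In this assay, hydrogen in place of ethoxy on a saturated chain carbon bound to an aromatic carbon and a saturated chain carbon gives a number 7 percentage points lower from compound 3 to compound 4 (within the scatter). Going by these compounds alone, this is the first direct reading of this position: with the core held constant, the 2-carboxy-1-ethoxyethyl and 2-carboxyethyl chains cannot be told apart by maximal response, so the ethoxy group, with its 3 heavy atoms and 1 hydrogen-bond acceptor, is not needed for the high maximal response of compound 4 at 140%. No supporting data bear on why the response holds after this change.

With only ethoxy and hydrogen shown on this carbon, it remains open whether a hydroxyl group, an amine or an alkoxy group with a longer chain would also leave the maximal response within the scatter. How the ethoxy group affects the concentration needed to reach that response also stays open, since the compounds shown here carry maximal response alone.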